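The source may report more compounds than this note shows. Statements on the series, on what has been measured and on what is new or still open speak of the compounds shown alone.

Measured in a functional assay (aorta) with Rattus norvegicus as the target; on this read-out lower numbers stand for stronger inhibition and higher numbers for weaker inhibition:
compound 1 `CC1(C)Oc2ccc(C#N)cc2[C@H](Nc2ccccc2)[C@H]1O` gives 1200 nM
compound 3 `CCCCOC(=O)CN(c1ccccc1)[C@H]1c2cc(C#N)ccc2OC(C)(C)[C@@H]1O` gives 27000 nM
compound 2 `CCOC(=O)CCCN(c1ccccc1)[C@H]1c2cc(C#N)ccc2OC(C)(C)[C@@H]1O` gives > 30000 nM, which is a limit of the assay and not a number the limit of > 30000 nM in this assay, at which 1 of the 3 values shown sits.

Among the measured compounds shown here, compound 3 holds the highest of the two numbers in this assay; the only other number lies a step of a 23-fold higher number from compound 1 to compound 3 (1.35 log units; beyond the scatter) away. Compound 4 `CCNC(=O)CN(c1ccccc1)[C@H]1c2cc(C#N)ccc2OC(C)(C)[C@@H]1O` differs from it by ethylamino in place of butoxy on a carbonyl carbon. For the measured compounds named here, no measured step turns the ester into an amide; the nearest comparison is an at least 1.1-fold lower number from compound 2 to compound 3 (0.04 log units; that floor lies within the scatter), a swap within the ester chain that stays within the scatter. The large steps of an at least 25-fold higher number from compound 1 to compound 2 (1.39 log units; beyond the scatter) and a 23-fold higher number from compound 1 to compound 3 (1.35 log units; beyond the scatter) arise from putting the ester-bearing chain on the nitrogen, which compound 4 keeps. Compound 4 is therefore expected to show a 1.1-fold lower number from compound 3 to compound 4 (0.05 log units; within the scatter) in this assay. Compound 4 is estimated at 24000 nM, within 8000 nM to 60000 nM.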

Compound 4, half-maximal inhibitory concentration: > 30000 nM
Compound 4 was reported as a limit; the forecaster's own chance of this, stated with the estimate: 35%; middle value at least 1.2-fold (0.09 log units) away from the limit.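

Ethylamino in place of butoxy on a carbonyl carbon gives an at least 1.1-fold higher number from compound 3 to compound 4 (0.04 log units; that floor lies within the scatter), so in this assay the amide cannot be told apart from the ester. The large step also holds for the amide chain, an at least 25-fold higher number from compound 1 to compound 4 (1.39 log units; beyond the scatter), and none of the nitrogen-substituted compound 2, compound 3 or compound 4 goes against it. The step between compound 2 and compound 4 cannot be read, since both values are limits: the limit of > 30000 nM in this assay, at which 2 of the 4 values shown sit.

On these data alone, whether a methyl on that nitrogen would keep the number of compound 1 stays open. So does the effect of a carboxylic acid or an amine at the end of the chain.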